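The source may hold more compounds than are shown below. What is called first, only, known or untested is meant among the compounds shown, and "the series" means these compounds.

Compound 3 `Nc1ccc2cccc(OCC3CCCO3)c2n1` stands at the edge of what an assay on cells with melanin-concentrating hormone receptor 1 (Homo sapiens) as the target, read by radioligand binding (on this read-out higher numbers stand for weaker inhibition and lower numbers for stronger inhibition), can report: compound 3 gives > 2000 nM, which is a limit of the measurement rather than a number (the limit of > 2000 nM in this assay, at which 1 of the 3 values shown sits). Two compounds with the same core sit inside the measurable range. Compound 1 `Nc1ccc2cccc(OCCC(F)(F)F)c2n1` gives 722 nM, and compound 2 `CC1CCC(Oc2cccc3ccc(N)nc23)C1` gives 823 nM; the difference between them is a 1.1-fold higher number from compound 1 to compound 2 (0.06 log units; within the scatter). Against these, the two steps toward the limit read an at least 2.7-fold higher number from compound 1 to compound 3 (0.44 log units; beyond the scatter) and an at least 2.4-fold higher number from compound 2 to compound 3 (0.38 log units; beyond the scatter). Compound 4 `CC#CCCOc1cccc2ccc(N)nc12` has not yet been measured. It differs from compound 3 by but-2-yn-1-yl in place of oxolan-2-yl on a saturated chain carbon bound to an oxygen on an aromatic ring. Going by the values given here, the steps that bear on this change are an at least 2.7-fold higher number from compound 1 to compound 3 (0.44 log units; beyond the scatter) and an at least 2.4-fold higher number from compound 2 to compound 3 (0.38 log units; beyond the scatter), both beyond the scatter, both ending at the limit. Among these three compounds, the groups with no ring hetero atom gave the lower numbers, whereas the oxolan-2-yl group of compound 3 sits at the limit. Compound 4 carries a group with no ring and no hydrogen-bond acceptor, so it is expected to move back toward the measurable range, a downward step of an at least 2.2-fold lower number from compound 3 to compound 4 (0.34 log units; beyond the scatter). Compound 4 is therefore estimated at 900 nM, with a range from 350 nM to 2500 nM.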

Compound 4, half-maximal inhibitory concentration: > 2000 nM
Compound 4: only a limit was reported; the forecaster's own chance of this, stated with the estimate: 20%; middle value at least 2.2-fold (0.34 log units) from the limit.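

In this assay, compound 4 gives a limit rather than a number, so a group with no ring and no hydrogen-bond acceptor in this place also ends at the limit: the limit of > 2000 nM in this assay, at which 2 of the 4 values shown sit. The readable steps are an at least 2.4-fold higher number from compound 2 to compound 4 (0.38 log units; beyond the scatter) and an at least 2.7-fold higher number from compound 1 to compound 4 (0.44 log units; beyond the scatter), so the pent-3-yn-1-yl group separates from the 3,3,3-trifluoropropyl and 3-methylcyclopentyl groups as clearly as the (oxolan-2-yl)methyl group does. Compound 4 therefore goes against the earlier pattern, in which only the ring oxygen group of compound 3 reached the limit, and the ring oxygen is not needed to reach it.

The step from compound 3 to compound 4 cannot be read, so these two compounds cannot be ordered. Going by these compounds, whether an amine, a carboxylic acid or a longer chain on this oxygen would give a number remains open.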